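A few compounds are considered here, and "the series" means these few. Any claim that something is new, unique, unknown or untested is made for them only; others in the source may bear on it.

Measured compounds:
compound 1, `CC(C)[C@@H](c1ccc(-c2ccc3cccc(F)c3c2)[nH]c1=O)[C@@H]1OC(=O)NC1=O`: 610 nM
compound 2, `CC(C)[C@H](C[C@H]1SC(=O)NC1=O)c1ccc(-c2ccc3cccc(F)c3c2)[nH]c1=O`: 9 nM

Among the measured compounds shown here, of these two numbers in a functional assay on CHO cells for antagonist activity at prostaglandin E2 receptor EP3 subtype (Homo sapiens), read by cAMP accumulation, with a stated time of 30 min (on this read-out lower numbers stand for stronger inhibition and higher numbers for weaker inhibition), compound 2 holds the lower one; the single measured step, a 68-fold lower number from compound 1 to compound 2 (1.83 log units; beyond the scatter), is large and beyond the scatter. Compound 3, `CC(C)[C@H](C[C@@H]1OC(=O)NC1=O)c1ccc(-c2ccc3cccc(F)c3c2)[nH]c1=O`, differs from compound 2 by 2,4-dioxo-1,3-oxazolidin-5-yl in place of 2,4-dioxo-1,3-thiazolidin-5-yl on a saturated chain carbon, two bonds along the chain from an aromatic carbon. That measured step bears on this change only in part, since it altered both the ring and the way the ring joins the chain, so a smaller shift toward a higher number is expected. The estimate for compound 3 is 30 nM, in the range 8 nM to 150 nM, meaning an expected 3.3-fold higher number from compound 2 to compound 3 (0.52 log units; beyond the scatter).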

Compound 3, half-maximal inhibitory concentration: 27 nM
The estimate for compound 3 lay 1.1-fold (0.05 log units) above the measured number; low and high end bracket the measured number.
By their numbers in this assay, from the lowest: compound 2; then compound 3; then compound 1.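

In this assay, the methyl link and the ring can now be told apart: with the oxazolidine ring kept, adding the link gives a 23-fold lower number from compound 1 to compound 3 (1.35 log units; beyond the scatter) and accounts for most of the gain seen with compound 2. Exchanging the ring's sulfur for oxygen, with the link kept, costs far less, as a 3.0-fold higher number from compound 2 to compound 3 (0.48 log units; beyond the scatter) is only modest. Nothing shown explains either step. The compounds shown leave open whether a carboxylic acid, or either ring on a longer chain such as an ethyl link, would do as well at this position.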